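This account rests on a few compounds, and the source may have more. Where it says the series, first, only, none or still open, it means among the compounds named here.

Working notes on the series. Compound 1 `CN1[C@H](COc2cccnc2)C[C@H]2C[C@H]21` and compound 2 `Clc1nccnc1OC[C@@H]1C[C@H]2C[C@H]2N1` share a bicyclic amine core carrying an aryloxymethyl arm, and both have been run in an assay on CHO-K1 cells for displacement of a labelled ligand from Neuronal acetylcholine receptor; alpha4/beta2 (Homo sapiens), read by scintillation counting; a lower number here means a stronger inhibitor, a higher number a weaker inhibitor. In this assay compound 1 gives 5.5 nM, while compound 2 gives 5110 nM, the higher of the two numbers by a margin well beyond the usual scatter; compound 2 therefore stands as the weaker of the pair. The two compounds differ in several places at once, so nothing can be said about which of those differences carries the gap.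

Compound 3 `c1cnc(OC[C@@H]2C[C@H]3C[C@H]3N2)cn1` has not yet been measured. It differs from compound 2 by hydrogen in place of chloro on an aromatic carbon, a hydrogen in place of chloro on an aromatic carbon. Among the measured compounds shown here, no single-change step of this kind has been measured, so the direction is open. Only a modest step in this assay is expected, from compound 2 to compound 3 a 1.7-fold lower number from compound 2 to compound 3 (0.23 log units; within the scatter), and the estimate for compound 3 is 3000 nM, with a range from 800 nM to 12000 nM.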

Compound 3, inhibition constant: > 10000 nM
Compound 3 ended at the assay's limit (the forecaster's own chance of this, stated with the estimate: 5%); middle value at least 3.3-fold (0.52 log units) from the limit.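

Compound 3 reads > 10000 nM in this assay, which is a limit of the assay and not a number. Among the compounds shown here, this gives the first single-change step, an at least 1.9-fold higher number from compound 2 to compound 3 (0.29 log units; that floor lies within the scatter), and it shows that hydrogen in place of chloro on an aromatic carbon next to the ring nitrogen brings no lower number, though the floor of the step alone does not establish a rise beyond the scatter. The full size of the step cannot be read because the value of compound 3 stops at the limit: the limit of > 10000 nM in this assay, at which 1 of the 3 values shown sits.

Going by these compounds, whether a bromo, a methyl or a methoxy group at this same carbon would give a lower number than chloro stays open. Also open, on these data alone, is whether the same change would matter on the core of compound 1, where the arm carries a different aromatic ring and the ring nitrogen of the core carries a methyl.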